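The compounds below may be only part of what the source reports. "The series", "measured", "known", "first", "only" and "open" are said of these compounds alone.

Compound 1, `O=C(Nc1cccc(F)c1)N1CCN(c2ccnc(Cl)n2)CC1`, gives 952 nM in an assay on isolated protein for antagonist activity at transient receptor potential cation channel subfamily V member 1 (Homo sapiens); on this read-out lower numbers stand for stronger inhibition and higher numbers for weaker inhibition.
Compound 2, `O=C(Nc1ccc(F)cc1)N1CCN(c2ccnc(Cl)n2)CC1`, gives 1140 nM in this assay.
Compound 3, `O=C(Nc1cccc(C(F)(F)F)c1)N1CCN(c2ccnc(Cl)n2)CC1`, gives 543 nM in this assay.

All three share one core and differ only in the ring attached to the amide-type nitrogen. Compounds 1 and 2 are built from the same atoms joined differently: 4-fluorophenyl in place of 3-fluorophenyl on an amide-type nitrogen. In this assay this gives a 1.2-fold higher number from compound 1 to compound 2 (0.08 log units; within the scatter). From compound 1 to compound 3 the change is trifluoromethyl in place of fluoro on an aromatic carbon, and in this assay it gives a 1.8-fold lower number from compound 1 to compound 3 (0.24 log units; within the scatter).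

Compound 4, `O=C(Nc1ccc(C(F)(F)F)cc1)N1CCN(c2ccnc(Cl)n2)CC1`, has not yet been measured. It arises from compound 2 by the same kind of change, (trifluoromethyl in place of fluoro on an aromatic carbon); the surroundings differ, since in compound 4 the group sits para to a large group, whereas in compound 3 it sits meta to a large group. Because the earlier step of a 1.8-fold lower number from compound 1 to compound 3 (0.24 log units; within the scatter) stayed within the scatter, a step of about the same size is expected here: a 1.8-fold lower number from compound 2 to compound 4 (0.24 log units; within the scatter). On that basis compound 4 is estimated at 650 nM in this assay, with a likely range from 300 nM to 1400 nM.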

Compound 4, half-maximal inhibitory concentration: 874 nM
For compound 4 the middle estimate is 1.3-fold (0.13 log units) below the measured one, and the stated range covers the measured number.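

Replacing fluoro with trifluoromethyl gives a 1.3-fold lower number from compound 2 to compound 4 (0.12 log units; within the scatter) in this assay, so with the group para to a large group this step also stays within the usual scatter. Set beside the earlier step, the same change shows no detectable difference between the two settings, so it carries over in this small series: the same change on two cores in this assay, a 1.8-fold lower number (0.24 log units; within the scatter) from compound 1 to compound 3 and a 1.3-fold lower number (0.12 log units; within the scatter) from compound 2 to compound 4, 1.3-fold (0.13 log units) apart, within the scatter of two such steps Both steps are small enough to be noise, however, so the data do not show that trifluoromethyl truly strengthens inhibition in either setting, and two pairs of compounds cannot establish a general rule.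

The compounds shown leave open what a clearly different group on the same aromatic ring, such as a methoxy group, a nitrile or an amine, would do to the number. They also leave open whether the fluoro-to-trifluoromethyl step would stay this small if the chlorine on the shared core were replaced by an amine or a longer carbon chain.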